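Swapping an Acetyl for an Oxazolyl on a Sulfonamide

The compounds below may be only part of what the source reports. "The series", "measured", "known", "first", "only" and "open" are said of these compounds alone.

Three measured compounds share one core. Compound 1 `Nc1ccc(S(=O)(=O)Nc2ccnc3cc(C(F)(F)F)ccc23)cc1` gives 93100 nM in a functional assay on HepG2 cells (Homo sapiens) for antiproliferative activity, read by sulforhodamine B assay, with a stated time of 48 h; on this read-out higher numbers stand for weaker inhibition and lower numbers for stronger inhibition. Compound 2 `O=C(Nc1ccccc1)Nc1ccc(S(=O)(=O)Nc2ccnc3cc(C(F)(F)F)ccc23)cc1` is reported as "not active" (no number reported) in this assay. Compound 3 `CC(=O)NS(=O)(=O)c1ccc(N/C(S)=N\c2ccnc3cc(C(F)(F)F)ccc23)cc1` gives 28400 nM in this assay, the lowest of the two numbers, and its gap to compound 1 lies beyond the usual scatter of the test. Compound 4 `Cc1cc(NS(=O)(=O)c2ccc(N/C(S)=N\c3ccnc4cc(C(F)(F)F)ccc34)cc2)on1` differs from compound 3 by 3-methyl-1,2-oxazol-5-yl in place of acetyl on a sulfonamide nitrogen; cut one bond further out, the same change reads acetamido to (3-methyl-1,2-oxazol-5-yl)amino. For the measured compounds named here, no measured pair shows this exact exchange, so the size of the step is open. A small improvement is expected for compound 4, amounting to a 1.4-fold lower number from compound 3 to compound 4 (0.15 log units; within the scatter). Compound 4 is therefore estimated at 20000 nM, within a range from 6000 nM to 60000 nM.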

Compound 4, half-maximal inhibitory concentration: 28500 nM
For compound 4 the middle estimate is 1.4-fold (0.15 log units) below the measured one; the range from low to high includes it.
By their numbers in this assay, from the lowest: compounds 3 and 4 (each within the scatter of the next); then compound 1.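

In this assay, 3-methyl-1,2-oxazol-5-yl in place of acetyl on a sulfonamide nitrogen gives a 1.0-fold higher number from compound 3 to compound 4 (0.00 log units; within the scatter), so this read-out does not separate the two groups. At this position, a larger group with a five-membered aromatic ring therefore leaves the number within the scatter of the acetyl compound. Nothing measured here explains this match. Still open, as far as these compounds go, is how a bare hydrogen, a longer acyl chain or a phenyl ring on that nitrogen would read, and whether any group at this position can shift the number beyond the scatter.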